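The source may report more compounds than this note shows. Statements on the series, on what has been measured and on what is new or still open speak of the compounds shown alone.

Measured in a physicochemical assay for lipophilicity, read by HPLC; a higher number here means a more lipophilic compound, a lower number a more polar compound:
- compound 1 `Cc1ccsc1C(=CCCN(C)C(CCN)C(=O)NCc1ccc(Cl)cc1)c1sccc1C` gives 5.85
- compound 2 `Cc1ccsc1C(=CCCN(C)C(CC(C)O)C(=O)NCc1ccc(Cl)cc1)c1sccc1C` gives 5.99; 6.77 (2 entries)
- compound 3 `Cc1ccsc1C(=CCCN(C)C(CCO)C(=O)NCc1ccc(Cl)cc1)c1sccc1C` gives 6.38

Of the two compounds with a single number in this assay, compound 1 stands lowest. The nearest single number gives the step of a number 0.53 log units higher from compound 1 to compound 3 (beyond the scatter), with hydroxy in place of amino on a saturated chain carbon. Compound 2 has no single number (the several entries of compound 2 in this assay, 5.99; 6.77 (2 entries)).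

Compound 4 `Cc1ccc(CNC(=O)C(CCN)N(C)CCC=C(c2sccc2C)c2sccc2C)cc1` has not yet been measured. Its difference from compound 1 is methyl in place of chloro on an aromatic carbon. For the measured compounds named here, no measured step covers this change. The only one, a number 0.53 log units higher from compound 1 to compound 3 (beyond the scatter), lies on a saturated chain carbon and serves only as a reference for size. Neither chloro nor methyl counts a hydrogen-bond donor or acceptor, so no step beyond the scatter is expected in this assay. The estimated step is a number 0.05 log units lower from compound 1 to compound 4 (within the scatter). For compound 4 the estimated value is 5.8, with an expected range from 5.4 to 6.25.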

Compound 4, partition coefficient: 6.61
The estimate for compound 4 lay 0.81 log units below the measured number, and the stated range ends below it.
By their numbers in this assay, from the lowest: compound 1; then compounds 3 and 4 (each within the scatter of the next).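

In this assay, the change from 4-chlorobenzyl to 4-methylbenzyl gives the first step read on the aromatic ring rather than the saturated chain: a number 0.76 log units higher from compound 1 to compound 4 (beyond the scatter). Chloro and methyl have the same counts of heavy atoms, hydrogen-bond donors and hydrogen-bond acceptors, so these counts alone do not settle the number at this position. The step is modest but beyond the scatter, and its exact size remains provisional, as entries for a single close analogue can also differ widely: the several entries of compound 2 in this assay, 5.99; 6.77 (2 entries)

As far as these compounds go, it remains open whether the same exchange gives a similar step on the hydroxy chain of compound 3. From the compounds shown here alone, how fluoro, methoxy or trifluoromethyl on this aromatic carbon would read in this assay is also open.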